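Shortening a Propoxy Chain: Compound 3 to Compound 4

The source may hold more compounds than are shown below. What is called first, only, known or untested is meant among the compounds shown, and "the series" means these compounds.

Three compounds were tested in a functional assay on MCF7 cells (Homo sapiens) for cytotoxicity, read by MTT assay, with a stated time of 72 h; on this read-out lower numbers stand for higher toxicity in this test and higher numbers for lower toxicity in this test. Compound 1 `COc1ccc(OC(=O)Nc2ccc([Se]C#N)cc2)cc1` gives 74100 nM. Compound 2 `CC(C)COC(=O)Nc1ccc([Se][Se]c2ccc(NC(=O)OCC(C)C)cc2)cc1` gives 80500 nM in this assay. Compound 3 `CCCOC(=O)Nc1ccc([Se]C#N)cc1` gives 67500 nM in this assay. Compound 3 thus sits alongside compound 1 and compound 2, with each gap between it and the other two within the usual scatter of repeated measurements, so no ordering among the three can be read from these numbers.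

The unmeasured compound 4 `CCOC(=O)Nc1ccc([Se]C#N)cc1` differs from compound 3 in one place: hydrogen in place of methyl on a saturated chain carbon, two bonds along the chain from an oxygen next to a carbonyl group. Read one bond further out, this is propoxy becoming ethoxy. Within the data shown here, no measured pair in this set shows a single-point change of this kind, so nothing here tells how this assay responds to it. The three measured values, carrying different groups on the shared core, all lie within the scatter of one another, which gives no ground to expect a move beyond the scatter in either direction. Compound 4 is therefore estimated at 70000 nM, with a range from 35000 nM to 140000 nM. The step this estimate means, a 1.0-fold higher number from compound 3 to compound 4 (0.02 log units; within the scatter), is expected to stay within the scatter.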

Compound 4, concentration lethal to 50% of the cells: 67800 nM
Estimate against measurement, compound 4: 1.0-fold (0.01 log units) above; the measured number falls inside the stated range.
By their numbers in this assay, from the lowest: compounds 3, 4, 1 and 2 (each within the scatter of the next).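

Among these compounds, compound 3 and compound 4 form the first pair here that differ in one place, and in this assay the change from propoxy to ethoxy gives a 1.0-fold higher number from compound 3 to compound 4 (0.00 log units; within the scatter). Among the compounds shown here, at this position, two bonds along the chain from an oxygen next to a carbonyl group, replacing methyl with hydrogen therefore produces no step that can be told from the scatter, something the earlier compounds, which shared no such pair, could not show. No measurement shown here offers an explanation for this result.

From the compounds shown here alone, whether a longer chain such as butoxy, or an amine or carboxylic acid at the end of this chain, would move the number beyond the scatter remains open. So does whether the shorter methoxy would read like ethoxy, and whether this same change would read the same way on another core.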